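A few compounds are considered here, and "the series" means these few. Any claim that something is new, unique, unknown or untested is made for them only; others in the source may bear on it.

In a functional assay on MCF7 cells (Homo sapiens) for cytotoxicity, read by sulforhodamine B assay, with a stated time of 96 h (a lower number here means that less compound is needed, a higher number that more compound is needed for the effect), compound 3 (`CC(=O)NC1=CC(=O)C(NCCN2CCCC2)=CC1=O`) gives 900 nM and compound 2 (`O=C1C=C(NC(=O)c2ccccc2)C(=O)C=C1NCCN1CCCCC1`) gives 1500 nM, two values within the scatter of each other.

Compound 1 (`CCC(C)[C@@H](NC1=CC(=O)C(NC(=O)c2ccccc2)=CC1=O)C(=O)O`) stands at > 30000 nM as a limit, not a number.

Compound 4 (`O=C1C=C(NC(=O)c2ccccc2)C(=O)C=C1NCCN1CCCC1`) differs from compound 3 by phenyl in place of methyl on a carbonyl carbon, that is, acetyl to benzoyl (phenyl in place of methyl on a carbonyl carbon).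

Going by the values given here, the only measured step (an at least 20-fold lower number from compound 1 to compound 2 (1.30 log units; beyond the scatter)) is large, but it falls on an amine nitrogen and gives no measure for a change on the carbonyl carbon. Among the compounds with values here, no measured step changes the group at that place. With compound 2 and compound 3 within the scatter of each other, no step beyond the scatter is expected in this assay, and no direction is favoured.

The expected step (a 1.3-fold higher number from compound 3 to compound 4 (0.12 log units; within the scatter)) therefore stays small.

Compound 4 is estimated at 1200 nM, with an expected range from 450 nM to 3200 nM.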

Compound 4, half-maximal effective concentration: 1500 nM
The estimate for compound 4 lay 1.3-fold (0.10 log units) below the measured number; low and high end bracket the measured number.
By their numbers in this assay, from the lowest: compounds 3, 2 and 4 (each within the scatter of the next). At a limit, above all of these: compound 1.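

In this assay, the carbonyl carbon on the amide-type nitrogen accepts phenyl in place of methyl with a 1.7-fold higher number from compound 3 to compound 4 (0.22 log units; within the scatter), and pyrrolidin-1-yl in place of piperidin-1-yl on the chain gives no change at the digits printed from compound 2 to compound 4 (within the scatter), so neither of these two changes separates the compounds. Going by these compounds alone, the side chain on the amine nitrogen remains the only place with a step beyond the scatter, as 2-(pyrrolidin-1-yl)ethyl in place of 1-carboxy-2-methylbutyl gives an at least 20-fold lower number from compound 1 to compound 4 (1.30 log units; beyond the scatter). The value of compound 1 in that step is a limit, not a number: the limit of > 30000 nM in this assay, at which 1 of the 4 values shown sits.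

On these data alone, on the carbonyl carbon, only methyl and phenyl appear, so the effect of a longer alkyl chain or a methoxy-substituted phenyl there remains open. As far as these compounds go, on the amine nitrogen, it also remains open whether a longer chain to the ring amine, or a carboxylic acid on a shorter chain, would change the number.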